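Urea aryl swap: dichlorophenyl to trifluoromethylphenyl on shared core

The compounds below may be only part of what the source reports. "The series", "measured", "known", "first", "only" and "open" are said of these compounds alone.

Measured compounds in a functional assay on NCI/ADR-RES cells (Homo sapiens) for inhibition, read by sulforhodamine B assay, with a stated time of 48 h; on this read-out higher numbers stand for weaker inhibition of growth and lower numbers for stronger inhibition of growth:
Compound 1 `COc1cc(-c2nn(-c3cccc(NC(=O)Nc4cc(C(F)(F)F)cc(C(F)(F)F)c4)c3)cc2-c2ccncc2)ccc1Cl`: 1010 nM
Compound 2 `COc1cc(-c2nn(-c3cccc(NC(=O)c4cccc(C(F)(F)F)c4)c3)cc2-c2ccncc2)ccc1Cl`: 1090 nM
Compound 3 `COc1cc(-c2nn(-c3cccc(NC(=O)Nc4ccc(Cl)c(Cl)c4)c3)cc2-c2ccncc2)ccc1Cl`: 990 nM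

Compound 3 holds the lowest of the three numbers, but its distance to compound 1 and to compound 2 falls within the scatter, so the three stand together. Compound 4 `COc1cc(-c2nn(-c3cccc(NC(=O)Nc4cccc(C(F)(F)F)c4)c3)cc2-c2ccncc2)ccc1Cl` arises from compound 3 by 3-(trifluoromethyl)phenyl in place of 3,4-dichlorophenyl on an amide-type nitrogen. Among the measured compounds shown here, only one measured step touches this region: a 1.1-fold lower number from compound 2 to compound 3 (0.04 log units; within the scatter), which trades a trifluoromethylphenyl amide for the dichlorophenyl urea and stays within the scatter. Compound 1, which also carries trifluoromethyl groups on the urea aryl, sits at the same level. For the measured compounds named here, no step here moves beyond the scatter, so for compound 4 a step of a 1.0-fold higher number from compound 3 to compound 4 (0.00 log units; within the scatter) is expected, neither direction favoured. Compound 4 is therefore estimated at 1000 nM, within 500 nM to 2000 nM.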

Compound 4, concentration for 50% growth inhibition: 783 nM
For compound 4 the middle estimate is 1.3-fold (0.11 log units) above the measured one; the measured number falls inside the stated range.
By their numbers in this assay, from the lowest: compounds 4, 3, 1 and 2 (each within the scatter of the next).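

In this assay, swapping 3,4-dichlorophenyl for 3-(trifluoromethyl)phenyl on the urea nitrogen does not separate the two compounds (a 1.3-fold lower number from compound 3 to compound 4 (0.10 log units; within the scatter)). Dropping one trifluoromethyl from the urea aryl also leaves them together (a 1.3-fold lower number from compound 1 to compound 4 (0.11 log units; within the scatter)), and with 3-(trifluoromethyl)phenyl held constant, so does the urea in place of the amide (a 1.4-fold lower number from compound 2 to compound 4 (0.14 log units; within the scatter)). No available evidence bears on this result. Still open, going by these compounds, is whether a carboxylic acid or an amine on this aryl ring would move the number beyond the scatter.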